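A few compounds are considered here, and "the series" means these few. Any claim that something is new, unique, unknown or untested is made for them only; others in the source may bear on it.

In a functional assay on HCT-116 cells (Homo sapiens) for antiproliferative activity, read by MTT assay, with a stated time of 48 h (on this read-out lower numbers stand for stronger inhibition and higher numbers for weaker inhibition), compound 2 `O=C(/C=C/c1ccccc1)c1nc2ccccc2[nH]1` gives 200 nM, the lowest of the three numbers recorded so far. Its nearest neighbour is compound 3 `COc1cccc(/C=C/C(=O)c2nc3ccccc3[nH]2)c1`, which gives 580 nM, and the furthest is compound 1 `O=C(/C=C/c1ccccc1Br)c1nc2ccccc2[nH]1`, which gives 16400 nM.

Compound 4 `Cc1ccccc1/C=C/C(=O)c1nc2ccccc2[nH]1` differs from compound 2 in one respect: methyl in place of hydrogen on an aromatic carbon, the change sitting on an aromatic carbon of a six-membered aromatic ring of carbon only, ortho to a large group.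

Among the measured compounds shown here, two measured steps bear on this. The first is an 82-fold lower number from compound 1 to compound 2 (1.91 log units; beyond the scatter), which shows that a substituent on that same ring position, in that case bromo, went with a large rise in the number. The second is a 2.9-fold higher number from compound 2 to compound 3 (0.46 log units; beyond the scatter), where methoxy placed elsewhere on the same ring gave a modest rise. Neither step involves methyl, and the methyl group enters at the position that carried bromo rather than methoxy, so the closer precedent is the larger one.

Compound 4 is therefore expected to show a number higher than compound 2, with a step of a 5.0-fold higher number from compound 2 to compound 4 (0.70 log units; beyond the scatter) smaller than that of bromo. The estimate for compound 4 is 1000 nM, with a range from 300 nM to 4000 nM.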

Compound 4, half-maximal inhibitory concentration: 860 nM
Compound 4: the middle estimate sits 1.2-fold (0.07 log units) above what was measured, and the stated range covers the measured number.
By their numbers in this assay, from the lowest: compound 2; then compounds 3 and 4 (each within the scatter of the next); then compound 1.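

In this assay, among the compounds shown here, methyl in place of hydrogen on an aromatic carbon ortho to a large group gives a 4.3-fold higher number from compound 2 to compound 4 (0.63 log units; beyond the scatter) and thus shows that bromo is not the only group that raises the number at this position. Methyl in place of bromo gives a 19-fold lower number from compound 1 to compound 4 (1.28 log units; beyond the scatter) at the same place, so the size of the rise depends on which group enters, something compound 1 alone could not show. No measured property is available to account for this difference between methyl and bromo.

The compounds shown leave open whether the rise follows from any group other than hydrogen at this position or whether a group such as fluoro, hydroxyl or an amine would leave the number close to that of compound 2. They also leave open how methoxy would behave at this position, since in compound 3 it sits elsewhere on the ring, and whether an ethyl group or a longer chain would extend the rise seen with methyl.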